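A few compounds are considered here, and "the series" means these few. Any claim that something is new, unique, unknown or untested is made for them only; others in the source may bear on it.

Measured so far:
compound 1 `Cc1cc(Nc2cc(-c3ccccc3)[nH]n2)n2nc(SCc3ccc(Br)cc3)nc2n1`: 2720 nM
compound 2 `Cc1cc(Nc2cc(-c3ccccc3)[nH]n2)n2nc(SCC(=O)c3ccccc3)nc2n1`: 5240 nM
compound 3 `Cc1cc(Nc2cc(-c3ccccc3)[nH]n2)n2nc(SCCCc3ccccc3)nc2n1`: 3900 nM

In a functional assay on MCF7 cells (Homo sapiens) for inhibition, read by MTT assay, with a stated time of 72 h (a higher number here means a weaker inhibitor, a lower number a stronger inhibitor), compound 3 gives 3900 nM, within the scatter of both other compounds. In compound 4 `Cc1cc(Nc2cc(-c3ccccc3)[nH]n2)n2nc(SCc3nc4ccccc4[nH]3)nc2n1`, 1H-benzimidazol-2-yl stands in place of phenethyl on a saturated chain carbon bound to a sulfur: 1H-benzimidazol-2-yl in place of phenethyl on a saturated chain carbon bound to a sulfur. Three measured steps at this place bear on the change: a 1.4-fold higher number from compound 1 to compound 3 (0.16 log units; within the scatter), a 1.3-fold lower number from compound 2 to compound 3 (0.13 log units; within the scatter) and a 1.9-fold higher number from compound 1 to compound 2 (0.28 log units; within the scatter). All three stay within the scatter, but none brings in a five-membered aromatic ring with 2 hetero atoms at this place. No step beyond the scatter is therefore expected in this assay, and no direction is favoured. The expected step is a 1.1-fold lower number from compound 3 to compound 4 (0.05 log units; within the scatter). The estimated value for compound 4 is 3500 nM, with an expected range of 1400 nM to 8000 nM.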

Compound 4, half-maximal inhibitory concentration: 2730 nM
Beside the measured number, compound 4's estimate is 1.3-fold (0.11 log units) above it; the measured number falls inside the stated range.
By their numbers in this assay, from the lowest: compounds 1, 4, 3 and 2 (each within the scatter of the next).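

In this assay the first five-membered aromatic ring with 2 hetero atoms at this place, in 1H-benzimidazol-2-yl, stays within the scatter of all three other groups (a 1.4-fold lower number from compound 3 to compound 4 (0.15 log units; within the scatter); a 1.9-fold lower number from compound 2 to compound 4 (0.28 log units; within the scatter); a 1.0-fold higher number from compound 1 to compound 4 (0.00 log units; within the scatter)). Bringing a hydrogen-bond donor and acceptor onto a saturated chain carbon bound to a sulfur thus gives no step beyond the scatter among these four compounds. Nothing at hand offers an explanation for this result. As far as these compounds go, whether an amine, a carboxylic acid or a longer chain at this place would give a step beyond the scatter remains open.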